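Aryl versus styryl on the saturated ring carbon

The source may hold more compounds than are shown below. What is called first, only, known or untested is meant among the compounds shown, and "the series" means these compounds.

For the measured compounds named here, compound 2 `Cc1cc(O)c(C2=NN(c3ccc(S(N)(=O)=O)cc3)C(/C=C/c3ccccc3)C2)cc1Cl` gives 37500 nM in a functional assay on HOP-62 cells (Homo sapiens) for antiproliferative activity, with a stated time of 48 h (on this read-out lower numbers stand for higher toxicity in this test and higher numbers for lower toxicity in this test), the highest of the two numbers so far; compound 1 `Cc1cc(O)c(C2=NN(c3ccc(S(N)(=O)=O)cc3)C(c3ccccc3O)C2)cc1Cl` gives 11700 nM. Going by the values given here, the single measured step, a 3.2-fold higher number from compound 1 to compound 2 (0.51 log units; beyond the scatter), bears on the change toward compound 3 `COc1ccc(C2CC(c3cc(Cl)c(C)cc3O)=NN2c2ccc(S(N)(=O)=O)cc2)c(OC)c1OC`: 2,3,4-trimethoxyphenyl in place of 2-phenylethenyl on a saturated ring carbon, which again places an aromatic ring directly on that carbon, as in compound 1. Among the compounds with values here, the trimethoxy pattern itself has no measured precedent here. Partly undoing that step, compound 3 is expected to show a modest step down, a 2.5-fold lower number from compound 2 to compound 3 (0.40 log units; beyond the scatter). The estimate for compound 3 is 15000 nM, with a range from 5000 nM to 45000 nM.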

Compound 3, concentration lethal to 50% of the cells: 9920 nM
Compound 3: the middle estimate sits 1.5-fold (0.18 log units) above what was measured; low and high end bracket the measured number.
By their numbers in this assay, from the lowest: compounds 3 and 1 (each within the scatter of the next); then compound 2.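

With 2,3,4-trimethoxyphenyl in place of 2-phenylethenyl on the saturated ring carbon, this assay shows a 3.8-fold lower number from compound 2 to compound 3 (0.58 log units; beyond the scatter), so the earlier separation of the 2-phenylethenyl compound from an aromatic ring on this carbon now holds for a second aromatic ring. Exchanging 2-hydroxyphenyl for 2,3,4-trimethoxyphenyl gives a 1.2-fold lower number from compound 1 to compound 3 (0.07 log units; within the scatter), so these two substitution patterns cannot be told apart in this test. No measured evidence accounts for either step.

Open, going by these compounds, is whether an unsubstituted phenyl ring reads like these two aromatic rings. Also open, on these data alone, is how a carboxylic acid or an amine on that ring would read.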